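A few compounds are considered here, and "the series" means these few. Any claim that something is new, unique, unknown or untested is made for them only; others in the source may bear on it.

Measured compounds:
- compound 1 `O=C(Nc1cccc(-n2cc(-c3ccncc3)c(-c3cc(O)cc(Cl)c3)n2)c1)Nc1ccc(Cl)c(Cl)c1`: 16.2%
- compound 2 `COc1cc(Cl)cc(-c2nn(-c3cccc(NC(=O)Nc4ccc(Cl)c(C(F)(F)F)c4)c3)cc2-c2ccncc2)c1`: 22.9%
- compound 3 `COc1cc(Cl)cc(-c2nn(-c3cccc(NC(=O)Nc4cc(C(F)(F)F)cc(C(F)(F)F)c4)c3)cc2-c2ccncc2)c1`: 14.2%

In a functional assay on SF-268 cells (Homo sapiens) for inhibition, read by sulforhodamine B assay, with a stated time of 48 h, tested at 10 uM (a higher number here means a weaker effect of the compound at the concentration tested, a lower number a stronger effect), compound 3 gives 14.2%, the lowest of the three numbers; compound 1 lies nearest to it and compound 2 furthest, yet both gaps remain within the scatter, so the three read as one level. Going by the values given here, no single-change step between measured compounds is available.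

Compound 4 `COc1cc(Cl)cc(-c2nn(-c3cccc(NC(=O)Nc4cccc(C(F)(F)F)c4)c3)cc2-c2ccncc2)c1` differs from compound 3 in one place: hydrogen in place of trifluoromethyl on an aromatic carbon. Among the compounds with values here, with no measured step to lean on, only a small change is expected in this assay, if any, and the numbers of compounds 1 to 3 suggest the level is held. The step of a number 6.8 percentage points higher from compound 3 to compound 4 (within the scatter) is estimated to stay within the scatter, perhaps drifting slightly upward. Compound 4 is thus expected to give 21%, with a range from 9% to 38%.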

Compound 4, a percentage reported as activity, at one concentration (the size of the read-out at that concentration, not a potency): 27.9%
Compound 4: the middle estimate sits 6.9 percentage points below what was measured; the range from low to high includes it.
By their numbers in this assay, from the lowest: compounds 3, 1, 2 and 4 (each within the scatter of the next, the first and the last beyond it).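

Hydrogen in place of trifluoromethyl gives in this assay the first single-change step of the series, a number 13.7 percentage points higher from compound 3 to compound 4 (beyond the scatter), so this place on the aromatic ring registers the change. Hydrogen in place of chloro on another aromatic carbon of that ring gives a number 5 percentage points higher from compound 2 to compound 4 (within the scatter), so that change is not resolved in this assay. Nothing available bears on why either step takes its size.

Open, on these data alone, is whether another group at the trifluoromethyl place, such as an amine, a methoxy or a carboxylic acid, would hold the level of compound 3. Also open, as far as these compounds go, is whether the same replacement would give a similar step on the core of compound 1.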